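This account rests on a few compounds, and the source may have more. Where it says the series, first, only, none or still open, it means among the compounds named here.

Of the compounds shown here, three sharing one core have been tested so far in a functional assay on MIA PaCa-2 cells (Homo sapiens) for inhibition, read by MTT assay, with a stated time of 4 days (a higher number here means a weaker inhibitor, a lower number a stronger inhibitor), on this series. Among the measured compounds shown here, compound 1 (`COc1cc(NC(C)CCCNC(=O)NNC(=O)NCCCCCO)c2ncccc2c1`) gives 168000 nM there, the only exact number of the three. Compound 2 (`COc1cc(NC(C)CCCNC(=O)NNC(=O)NC(CO)(CO)CO)c2ncccc2c1`) reaches only a limit, > 250000 nM in this test. Going by these compounds, compound 3 (`COc1cc(NC(C)CCCNC(=O)NNC(=O)N(CCO)CCO)c2ncccc2c1`) also stops at a limit, > 250000 nM in this test, so its true position is unknown.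

Compound 4 (`COc1cc(NC(C)CCCNC(=O)Nc2ccc(Cl)c(C(F)(F)F)c2)c2ncccc2c1`) has 4-chloro-3-(trifluoromethyl)phenyl in place of (bis(2-hydroxyethyl)carbamoyl)amino on an amide-type nitrogen. The measured steps help little. They show an at least 1.4-fold higher number from compound 1 to compound 2 (0.17 log units; that floor lies within the scatter) and an at least 1.4-fold higher number from compound 1 to compound 3 (0.17 log units; that floor lies within the scatter) as well as a step that the two limits leave unreadable from compound 2 to compound 3 in this series. Each only exchanges one hydroxy-bearing group for another, and none introduces an aromatic ring, so none sizes this change.

A large move toward a lower number is still expected in this assay, since even compound 1 sits at 168000 nM in this test. The expected change is an at least 12-fold lower number from compound 3 to compound 4 (1.09 log units; beyond the scatter) by this estimate. For compound 4 the estimated value is 20000 nM with an expected range from 5000 nM to 70000 nM in this test.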

Compound 4, half-maximal inhibitory concentration: 4000 nM
Estimate against measurement, compound 4: 5.0-fold (0.70 log units) above; measured number outside the range, below it.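

In this assay, among the compounds shown here, this place on an amide-type nitrogen proves highly sensitive to the group it carries: the earlier exchanges among hydroxy-bearing groups gave no readable step beyond the scatter, whereas 4-chloro-3-(trifluoromethyl)phenyl gives a 42-fold lower number from compound 1 to compound 4 (1.62 log units; beyond the scatter), the only exact step of the three. The other two changes are also large, with an at least 62-fold lower number from compound 3 to compound 4 (1.79 log units; beyond the scatter) and an at least 62-fold lower number from compound 2 to compound 4 (1.79 log units; beyond the scatter). Those two sizes are only floors, and the true steps may be larger, because each starts from a limit rather than a number: the limit of > 250000 nM in this assay, at which 2 of the 4 values shown sit.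

The change brings in an aromatic ring, chlorine and trifluoromethyl together and removes all hydrogen-bond donors of the group it replaces, so the compounds shown cannot say which part matters. Going by these compounds, how an unsubstituted phenyl ring, or a phenyl ring carrying only chlorine, would behave at this place in this assay stays open.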